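From 2-methylphenyl to 5-fluoro-2-methoxyphenyl

This account rests on a few compounds, and the source may have more. Where it says the series, first, only, none or still open, it means among the compounds named here.

Compound 1 (`COc1ccc(-n2cnc3cnc(Nc4cccc(NC(C)=O)c4)cc32)cc1OC`): 140 nM
Compound 2 (`COc1ccc(-n2cnc3cnc(-c4cccc(NC(C)=O)c4)cc32)cc1OC`): > 30000 nM (a limit, not a number)
Compound 3 (`COc1ccc(-n2cnc3cnc(-c4ccccc4C)cc32)cc1OC`): 69 nM

All three results come from a functional assay on HL-60 cells (Homo sapiens) for activation, read by flow cytometry, with a stated time of 4 days (a lower number here means that less compound is needed, a higher number that more compound is needed for the effect), and are half-maximal effective concentrations. Compound 3 (69 nM) has the lower of the two actual numbers. Compound 1 (140 nM) is its nearest neighbour, and the gap between them lies beyond the usual scatter. Compound 2 gives no number, only a limit (> 30000 nM).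

The next compound, compound 4 (`COc1ccc(-n2cnc3cnc(-c4cc(F)ccc4OC)cc32)cc1OC`), has 5-fluoro-2-methoxyphenyl in place of 2-methylphenyl on an aromatic carbon. Within the data shown here, no pair of measured compounds differs in one place alone, so no measured step can serve as a guide. Both the leaving and entering groups hold one six-membered aromatic ring of carbon only, and compound 3 (69 nM) shows that such a group on this carbon can give a low number. Compound 2, which also carries such a ring there, goes against any wider reading, with > 30000 nM as a limit. In this assay the expected change is small and slightly upward, with the estimated step of a 1.2-fold higher number from compound 3 to compound 4 (0.06 log units; within the scatter) staying within the scatter. For compound 4 the expected value is 80 nM (estimated range 25 nM to 300 nM).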

Compound 4, half-maximal effective concentration: 1300 nM
Beside the measured number, compound 4's estimate is 16-fold (1.21 log units) below it; measured number above the stated range.
By their numbers in this assay, from the lowest: compound 3; then compound 1; then compound 4. At a limit, above all of these: compound 2.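

Among these compounds, measured in this assay the replacement of 2-methylphenyl by 5-fluoro-2-methoxyphenyl gives a 19-fold higher number from compound 3 to compound 4 (1.28 log units; beyond the scatter) on this aromatic carbon, and it is the first step at this position that can be read directly. Both groups hold one six-membered aromatic ring of carbon only, so this step shows that having such a ring on this carbon does not by itself secure a low number: what the ring carries matters here, and the change in this one place moves the result well beyond the scatter. Nothing measured among these compounds accounts for the size of this step or for a property of either group.

The entering group differs from the leaving one in two ways at once, with a methoxy group in place of the methyl and a fluorine added, and the compounds shown leave open which of these goes with the higher number. Plain 2-methoxyphenyl, 3-fluoro-2-methylphenyl or a ring bearing an amine or a carboxylic acid would each test a different part of that question at this position.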